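Thiomorpholine Carbonyl Replaces the Sulfamoylthiophene Arm

The source may hold more compounds than are shown below. What is called first, only, known or untested is meant among the compounds shown, and "the series" means these compounds.

Of the compounds shown here, two have been measured in an assay (Rattus norvegicus) for inhibition of Fatty-acid amide hydrolase 1 (Homo sapiens); on this read-out higher numbers stand for weaker inhibition and lower numbers for stronger inhibition. Compound 1 `NC(=O)c1cccc(-c2cnc(C(=O)CCCCCCc3ccccc3)o2)c1` gives 6 nM, and compound 2 `NS(=O)(=O)c1ccc(-c2cnc(C(=O)CCCCCCc3ccccc3)o2)s1` gives 3 nM. Going by the values given here, the single step between them, a 2.0-fold lower number from compound 1 to compound 2 (0.30 log units; within the scatter), lies within the scatter, so neither compound stands apart from the other; compound 2 simply carries the lower of the two numbers without any difference that can be trusted.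

Compound 3 `O=C(CCCCCCc1ccccc1)c1ncc(C(=O)N2CCSCC2)o1` is the next compound to be measured. Its change from compound 2 is (thiomorpholin-4-yl)carbonyl in place of 5-sulfamoylthiophen-2-yl on an aromatic carbon. Among the compounds with values here, the one measured step, from compound 1 to compound 2, swaps one aromatic group for another and says nothing about trading the aromatic arm for an amide-linked saturated ring, so it does not bear on this change. Within the data shown here, with no step to lean on, the expectation rests on the two values alone: the number for compound 3 is expected to come out somewhat higher than that of compound 2, a step of a 6.7-fold higher number from compound 2 to compound 3 (0.82 log units; beyond the scatter), though the range is wide. The estimate for compound 3 in this assay is 20 nM, between 4 nM and 100 nM.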

Compound 3, inhibition constant: 10 nM
For compound 3 the middle estimate is 2.0-fold (0.30 log units) above the measured one; the measured number falls inside the stated range.
By their numbers in this assay, from the lowest: compounds 2, 1 and 3 (each within the scatter of the next, the first and the last beyond it).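

At the aromatic carbon next to the ring oxygen, these values show that an aromatic arm is not needed for a low number in this assay: replacing 5-sulfamoylthiophen-2-yl with the non-aromatic (thiomorpholin-4-yl)carbonyl group, which carries 0 hydrogen-bond donors where the group it replaces carries 1, gives a 3.3-fold higher number from compound 2 to compound 3 (0.52 log units; beyond the scatter). Set against the other aromatic arm, the same group gives a 1.7-fold higher number from compound 1 to compound 3 (0.22 log units; within the scatter), so compound 3 cannot be told apart from compound 1 in this assay, and only compound 2 separates from compound 3. No supporting data accompany these values to explain why the swap has an effect of this size.

With a single amide-linked saturated ring among the compounds shown, it remains open whether the ring sulfur contributes anything, a question that a morpholin-4-ylcarbonyl group, with oxygen in its place, or an open dimethylamide would address. Also open, on these data alone, is how a carboxylic acid or a simple amine at this same carbon would read out, and whether the result for the thiomorpholine amide holds with a shorter chain in place of the one shared by all three compounds.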